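Moving the Thiophene Link Within a Shared Core

The compounds below may be only part of what the source reports. "The series", "measured", "known", "first", "only" and "open" are said of these compounds alone.

Compound 1 `O=C(/C=C/c1ccsc1)c1cc(O)c(O)c([N+](=O)[O-])c1` gives 41400 nM in an assay on isolated protein for inhibition of Amine oxidase [flavin-containing] A (Homo sapiens), read by fluorescence; on this read-out lower numbers stand for stronger inhibition and higher numbers for weaker inhibition. Going by the values given here, only one other number is known: compound 2 `N#Cc1ccc(/C=C/C(=O)c2cc(O)c(O)c([N+](=O)[O-])c2)cc1` gives 45300 nM in this assay, and the two values sit within the usual scatter of each other, so neither stands apart. Compound 3 `O=C(/C=C/c1cccs1)c1cc(O)c(O)c([N+](=O)[O-])c1` differs from compound 1 only in thiophen-2-yl in place of thiophen-3-yl on a double-bonded chain carbon bound to a double-bonded chain carbon. Among the compounds with values here, no measured pair shows how such a swap plays out here, so no step beyond the scatter is expected, in either direction. For compound 3 the expected value in this assay is 40000 nM, within 15000 nM to 105000 nM. That estimate for compound 3 amounts to an expected step of a 1.0-fold lower number from compound 1 to compound 3 (0.01 log units; within the scatter).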

Compound 3, half-maximal inhibitory concentration: 49900 nM
For compound 3 the middle estimate is 1.2-fold (0.10 log units) below the measured one, and the stated range covers the measured number.
By their numbers in this assay, from the lowest: compounds 1, 2 and 3 (each within the scatter of the next).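

Going by these compounds alone, this is the first measured swap at this place: in this assay putting thiophen-2-yl in place of thiophen-3-yl gives a 1.2-fold higher number from compound 1 to compound 3 (0.08 log units; within the scatter). For this pair, then, changing which ring carbon carries the chain produces no difference that this read-out can separate. Nothing measured here offers an explanation for this result.

On these data alone, it remains open whether a furan ring or a pyridine ring at this place would shift the number beyond the scatter. The contribution of the groups on the shared core also remains open, since all the compounds shown carry them unchanged.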